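A few compounds are considered here, and "the series" means these few. Any claim that something is new, unique, unknown or untested is made for them only; others in the source may bear on it.

Measured so far:
compound 1 `C[C@@H](NC(=O)Nc1cccc(C(F)(F)F)c1)c1ccccc1`: 70%
compound 2 `C[C@@H](NC(=O)Nc1cccc(Cl)c1)c1ccccc1`: 83%

For the measured compounds named here, in an ADME assay on the whole organism with Oryza sativa as the target, tested at 10 uM (a higher number here means a weaker effect of the compound at the concentration tested, a lower number a stronger effect), compound 2 gives 83%, the highest of the two numbers; the only other number is that of compound 1, at 70%. Going by the values given here, the one measured step is a number 13 percentage points higher from compound 1 to compound 2 (beyond the scatter). Compound 3 `C[C@@H](NC(=O)Nc1cccc(Br)c1)c1ccccc1` differs from compound 2 by bromo in place of chloro on an aromatic carbon. Among the compounds with values here, that measured step exchanged a different pair of groups at the same place and so bears on this change only loosely; no step involving bromo has been measured. The account therefore expects no step beyond the scatter, a number 3 percentage points lower from compound 2 to compound 3 (within the scatter). Compound 3 is estimated at 80%, with a range from 65% to 95%.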

Compound 3, a percentage reported as activity, at one concentration (the size of the read-out at that concentration, not a potency): 99%
The estimate for compound 3 lay 19 percentage points below the measured number; measured number above the stated range.
By their numbers in this assay, from the lowest: compound 1; then compound 2; then compound 3.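

Bromo in place of chloro on this aromatic carbon is not a silent exchange in this assay: it brings a number 16 percentage points higher from compound 2 to compound 3 (beyond the scatter). Bromo in place of trifluoromethyl brings a number 29 percentage points higher from compound 1 to compound 3 (beyond the scatter), so compound 3 shows the weakest effect of the three, and the group at this one place alone separates all three compounds by more than the scatter. Nothing measured here accounts for this order.

As far as these compounds go, whether fluoro, methoxy or a nitrile at this place would fall within the span of these three groups stays open. So does whether the same order would hold with these groups elsewhere on the ring.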